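Dropping the Chloro Group: Expectation for Compound 3

The compounds below may be only part of what the source reports. "The series", "measured", "known", "first", "only" and "open" are said of these compounds alone.

The two measured compounds were tested in a functional assay on Huh-7 cells (Homo sapiens) for inhibition, read by MTT assay, with a stated time of 48 h; on this read-out lower numbers stand for stronger inhibition and higher numbers for weaker inhibition. Compound 1 `COc1cc2ccc(=O)oc2cc1OC(=O)c1c(C)noc1-c1ccccc1F` reached only the edge of the method: in this assay compound 1 gives > 25000 nM, which is a limit rather than a number. Compound 2 `COc1cc2ccc(=O)oc2cc1OC(=O)c1c(-c2ccc(Cl)cc2)n[nH]c1C` is the sole member with a measured figure; in this assay compound 2 gives 16200 nM, the only number among the results shown. The other result is the limit of > 25000 nM in this assay, at which 1 of the 2 values shown sits. Compound 3 `COc1cc2ccc(=O)oc2cc1OC(=O)c1c(-c2ccccc2)n[nH]c1C` has not yet been measured. It differs from compound 2 by hydrogen in place of chloro on an aromatic carbon, the same difference reading, one bond further out, as 4-chlorophenyl to phenyl. For the measured compounds named here, no step between measured compounds is available to calibrate this change. The step that is expected, a 1.4-fold higher number from compound 2 to compound 3 (0.13 log units; within the scatter), is a modest weakening that may not exceed the usual scatter. Compound 3 is therefore estimated at 22000 nM, between 8000 nM and 60000 nM, with a fair chance that only a limit is reported.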

Compound 3, half-maximal inhibitory concentration: > 25000 nM
Compound 3 gave a limit, no number (the forecaster's own chance of this, stated with the estimate: 45%); middle value at least 1.1-fold (0.05 log units) away from the limit.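

In this assay, hydrogen in place of chloro on the aromatic carbon gives an at least 1.5-fold higher number from compound 2 to compound 3 (0.18 log units; that floor lies within the scatter), the first step read at this position, and it fixes only a floor that does not clear the usual scatter. Compound 3 gives > 25000 nM, which is a limit and not a number. The chloro group of compound 2 thus marks the only compound here with a measured figure, though the size of the change stays unresolved, and the series now sits mostly at the edge of the method: the limit of > 25000 nM in this assay, at which 2 of the 3 values shown sit.

The compounds shown leave open whether a fluoro, a methoxy or an amine in the same place would give a measured number, and how that number would compare with compound 2. From the compounds shown here alone, how far the true value of compound 3 lies past its limit also remains unknown.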